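A few compounds are considered here, and "the series" means these few. Any claim that something is new, unique, unknown or untested is made for them only; others in the source may bear on it.

Compound 2 `CNC(=O)N1CCN(S(=O)(=O)N2CC=C(c3ccc(F)cc3)CC2)[C@@H](C(=O)NO)C1` stands lowest of the two numbers in an ADME assay on the whole organism with Rattus norvegicus as the target, at a dose of 30 mg/kg by the oral route (on this read-out lower numbers stand for lower exposure and higher numbers for higher exposure at the dose given), where compound 2 gives 1790 ng.h/mL while compound 1 `CN(C)C(=O)N1CCN(S(=O)(=O)N2CC=C(c3ccc(F)cc3)CC2)[C@@H](C(=O)NO)C1` gives 6180 ng.h/mL. Compound 3 `O=C(NO)[C@H]1CN(C(=O)N2CCOCC2)CCN1S(=O)(=O)N1CC=C(c2ccc(F)cc2)CC1` differs from compound 2 in one place: morpholin-4-yl in place of methylamino on a carbonyl carbon. Within the data shown here, only one measured step bears on this, a 3.5-fold lower number from compound 1 to compound 2 (0.54 log units; beyond the scatter), in which a hydrogen-bond donor appeared on the amide-type nitrogen and exposure fell. Compound 3 again carries no donor there, so a rise back toward compound 1 is expected because a 3.5-fold lower number from compound 1 to compound 2 (0.54 log units; beyond the scatter) points that way. Compound 3 is estimated at 4000 ng.h/mL, within 1500 ng.h/mL to 11000 ng.h/mL, a step of a 2.2-fold higher number from compound 2 to compound 3 (0.35 log units; beyond the scatter).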

Compound 3, area under the concentration-time curve: 7940 ng.h/mL
Beside the measured number, compound 3's estimate is 2.0-fold (0.30 log units) below it; low and high end bracket the measured number.
By their numbers in this assay, from the lowest: compound 2; then compounds 1 and 3 (each within the scatter of the next).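

In this assay, morpholin-4-yl in place of methylamino on the carbonyl carbon gives a 4.4-fold higher number from compound 2 to compound 3 (0.65 log units; beyond the scatter), so this position accepts a six-membered ring without loss of exposure. Set against dimethylamino, the same ring gives a 1.3-fold higher number from compound 1 to compound 3 (0.11 log units; within the scatter), which places compounds 1 and 3 level and leaves compound 2, with its amide hydrogen, alone at the low end. No measurement shown here accounts for this. Still open, going by these compounds, is whether piperazin-1-yl or diethylamino on this carbonyl carbon would stay level with compounds 1 and 3.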